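A few compounds are considered here, and "the series" means these few. Any claim that something is new, unique, unknown or untested is made for them only; others in the source may bear on it.

Compound 1 `CCCn1c(=O)[nH]c2nc(-c3ccc(S(=O)(=O)N4CCN(c5ccc(Cl)cc5F)CC4)cc3)[nH]c2c1=O` — > 1000 nM in an assay on CHO cells for displacement of a labelled ligand from adenosine receptor A1 (Homo sapiens), read by scintillation counting, with a stated time of 90 min, in the presence of a further agent that is not named here; on this read-out higher numbers stand for weaker inhibition and lower numbers for stronger inhibition
Compound 2 `CCCn1c(=O)[nH]c2nc(-c3ccc(S(=O)(=O)N4CCN(C)CC4)cc3)[nH]c2c1=O` — 334 nM

In this assay compound 1 gives only a limit, > 1000 nM, and so stands at the limit of > 1000 nM in this assay, at which 1 of the 2 values shown sits. Compound 2 gives 334 nM. Among the compounds with values here, the one measured step, an at least 2.9-fold lower number from compound 1 to compound 2 (0.47 log units; beyond the scatter), puts methyl in place of 4-chloro-2-fluorophenyl on an amine nitrogen in a ring. Compound 3 `CCCn1c(=O)[nH]c2nc(-c3ccc(S(=O)(=O)N4CCN(Cc5ccc(Br)cc5)CC4)cc3)[nH]c2c1=O` differs from compound 1 by 4-bromobenzyl in place of 4-chloro-2-fluorophenyl on an amine nitrogen in a ring, so an aromatic ring stays on that nitrogen and the measured step is only a loose guide. Compound 3 is therefore expected to remain near the limit, a step that the limit leaves unreadable from compound 1 to compound 3. The estimate for compound 3 is 1500 nM, expected between 400 nM and 6000 nM.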

Compound 3, inhibition constant: > 1000 nM
Compound 3: a limit, no number (the forecaster's own chance of this, stated with the estimate: 60%); the middle value does not contradict the limit.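

In this assay compound 3 gives only a limit (> 1000 nM) and no number. The step from compound 1 to compound 3 cannot be read, as both values are limits: the limit of > 1000 nM in this assay, at which 2 of the 3 values shown sit. What can be read is an at least 2.9-fold higher number from compound 2 to compound 3 (0.47 log units; beyond the scatter) on replacing methyl with 4-bromobenzyl, so 4-bromobenzyl, like 4-chloro-2-fluorophenyl, leaves the number higher than that of compound 2. From the compounds shown here alone, how far either aromatic group lies past the limit stays open. So does whether ethyl or 2-hydroxyethyl on that amine nitrogen would stay close to compound 2.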